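Formyl for Methyl on the Ring Nitrogen: Expected Clearance

This account rests on a few compounds, and the source may have more. Where it says the series, first, only, none or still open, it means among the compounds named here.

Compound 1, `O=C(N[C@H]1CN(S(=O)(=O)c2ccccc2)C[C@@H]1C(=O)N[C@H]1CCCNC1)c1cc(-c2ccccc2Cl)on1`, gives 8.3 uL/min in an ADME assay on cells (Hepatocyte, Rattus norvegicus) for metabolic stability; a higher number here means faster removal of the compound, a lower number slower removal.
Compound 2, `CN(C(=O)[C@H]1CN(S(=O)(=O)c2ccccc2)C[C@@H]1NC(=O)c1cc(-c2ccccc2Cl)on1)[C@H]1CCCNC1`, gives 5.8 uL/min in this assay.
Compound 3, `CN1CCC[C@H](NC(=O)[C@H]2CN(S(=O)(=O)c3ccccc3)C[C@@H]2NC(=O)c2cc(-c3ccccc3Cl)on2)C1`, gives 31 uL/min in this assay.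

Compound 3 has the highest number of the three: a 3.7-fold higher number from compound 1 to compound 3 (0.57 log units; beyond the scatter) and a 5.3-fold higher number from compound 2 to compound 3 (0.73 log units; beyond the scatter). Compound 4, `O=CN1CCC[C@H](NC(=O)[C@H]2CN(S(=O)(=O)c3ccccc3)C[C@@H]2NC(=O)c2cc(-c3ccccc3Cl)on2)C1`, differs from compound 3 by formyl in place of methyl on an amine nitrogen in a ring. Among the measured compounds shown here, no measured pair shows formyl entering; the only step at this position is a 3.7-fold higher number from compound 1 to compound 3 (0.57 log units; beyond the scatter), where methyl replaced hydrogen. Formyl removes that methyl but adds something new, so a modest move downward toward compound 1 is expected, with wide uncertainty. In this assay compound 4 is estimated at 14 uL/min, with a range of 6 uL/min to 35 uL/min, meaning an expected step of a 2.2-fold lower number from compound 3 to compound 4 (0.35 log units; beyond the scatter).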

Compound 4, intrinsic clearance in a liver preparation (reported as CLH), per the amount of preparation that the assay uses in the Hepatocyte assay: 97 uL/min
The estimate for compound 4 lay 6.9-fold (0.84 log units) below the measured number; the measured number lies above the stated range.
By their numbers in the Hepatocyte assay, from the lowest: compounds 2 and 1 (each within the scatter of the next); then compound 3; then compound 4.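

At this ring nitrogen, swapping methyl for formyl does not bring the number in the Hepatocyte assay back toward that of the compound with hydrogen there; it moves further away, with a 3.1-fold higher number from compound 3 to compound 4 (0.50 log units; beyond the scatter), alongside a 12-fold higher number from compound 1 to compound 4 (1.07 log units; beyond the scatter) and a 17-fold higher number from compound 2 to compound 4 (1.22 log units; beyond the scatter). Compound 4 thus has the highest number of the four. In a physicochemical assay for solubility, at pH 7.4 (a higher number here means a more soluble compound, a lower number a less soluble compound), compound 3 gives 503000 nM and compound 4 gives 4500 nM, so this one change also comes with a much lower solubility number.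

From the compounds shown here alone, whether these shifts belong to formyl alone or to any carbonyl group on this nitrogen remains open. An acetyl group or a longer acyl chain there would help separate the two.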